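A few compounds are considered here, and "the series" means these few. Any claim that something is new, unique, unknown or untested is made for them only; others in the source may bear on it.

For the measured compounds named here, in a functional assay on HL-60 cells (Homo sapiens) for antiproliferative activity, read by sulforhodamine B assay, with a stated time of 72 h (a higher number here means a weaker inhibitor, a lower number a stronger inhibitor), compound 1 `S=C(NNc1nncc2ccccc12)Nc1ccccc1` gives 95 nM and compound 2 `O=S(=O)(Nc1ncccn1)c1ccc(Nc2nncc3ccccc23)cc1` gives 67 nM as the only other value, and the two lie within the usual scatter of each other. Compound 3 `COc1ccc(NC(=S)NNc2nncc3ccccc23)cc1` follows from compound 1 through the change methoxy in place of hydrogen on an aromatic carbon with methoxy in place of hydrogen on an aromatic carbon, para to a large group. Going by the values given here, no measured pair shows this change, so in this assay a step within the scatter is expected, with no direction favoured. The expected move is a 1.2-fold lower number from compound 1 to compound 3 (0.07 log units; within the scatter) as an estimate only. For compound 3 the estimated value is 80 nM with an expected range from 25 nM to 260 nM in this read-out.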

Compound 3, half-maximal inhibitory concentration: 74 nM
Compound 3: middle estimate off by 1.1-fold (0.03 log units), on the high side; low and high end bracket the measured number.
By their numbers in this assay, from the lowest: compounds 2, 3 and 1 (each within the scatter of the next).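

In this assay, for the compounds shown here, methoxy in place of hydrogen on an aromatic carbon, para to a large group, gives a 1.3-fold lower number from compound 1 to compound 3 (0.11 log units; within the scatter) and is the first measured step at this position. The position therefore accepts methoxy with no change beyond the scatter, though one pair cannot define a trend. No measurement shown here explains this result.

On these data alone, whether an amine, a carboxylic acid or a longer chain at this position would give a step beyond the scatter remains open. So does the outcome of methoxy at any other carbon of this ring.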